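The compounds below may be only part of what the source reports. "The series", "measured", "known", "first", "only" and "open" are said of these compounds alone.

Compound 1, `O=C(NO)c1ccc(NCc2nc(-c3ccccc3)nn2-c2ccccc2)cc1`: in an assay on Sf9 cells for inhibition of protein deacetylase HDAC6 (Homo sapiens), read by fluorescence, with a stated time of 40 min, tested at 100 nM (a higher number here means more inhibition at the concentration tested (going by the name of the read-out), a lower number less inhibition), compound 1 gives 72.6%.
Compound 2, `Cc1cccc(-c2nc(CNc3ccc(C(=O)NO)cc3)n(-c3ccccc3)n2)c1`: in this assay compound 2 gives 64.1%.

Within the data shown here, only these two compounds have been measured, so compound 2 stands with a single neighbour, compound 1, and the one step between them, a number 8.5 percentage points lower from compound 1 to compound 2 (within the scatter), lies within the scatter; neither compound stands apart from the other. Compound 3, `Cc1ccsc1-c1nc(CNc2ccc(C(=O)NO)cc2)n(-c2ccccc2)n1`, has not yet been measured in this assay. It differs from compound 2 in one place: 3-methylthiophen-2-yl in place of 3-methylphenyl on an aromatic carbon. Among the measured compounds shown here, no measured step involves an exchange of this kind. For the measured compounds named here, the only step at hand, a number 8.5 percentage points lower from compound 1 to compound 2 (within the scatter), concerns a methyl in place of hydrogen elsewhere in the molecule and stayed within the scatter, so it offers no direction for the present change and no sign that the shared core of compound 2 is sensitive to a change at this position. With nothing pointing either way, the expected step for compound 3 is a number 1.1 percentage points lower from compound 2 to compound 3 (within the scatter), which is no step beyond the scatter. Compound 3 is accordingly estimated at 63%, with a range from 47% to 78%.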

Compound 3, a percentage reported as inhibition, at one concentration (the size of the read-out at that concentration, not a potency): 72.1%
Compound 3: the middle estimate sits 9.1 percentage points below what was measured, within the range that was stated.
By their numbers in this assay, from the lowest: compounds 2, 3 and 1 (each within the scatter of the next).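

In this assay, exchanging the ring itself on the aromatic carbon between two ring nitrogen atoms gives a number 8 percentage points higher from compound 2 to compound 3 (within the scatter), and 3-methylthiophen-2-yl in place of phenyl gives a number 0.5 percentage points lower from compound 1 to compound 3 (within the scatter). The earlier step covered only a methyl on the phenyl ring, whereas these two show that a five-membered aromatic ring with a sulfur atom can take the place of either six-membered ring with no step beyond the scatter, so all three groups at this position read alike at the single concentration tested. The compounds shown offer nothing that would account for these numbers at the level of structure, and no separate measurement bears on them.

On these data alone, all three groups here are aromatic rings, so it remains open whether a saturated ring such as cyclohexyl, an amine or a carboxylic acid at the same place would stay within the scatter of these numbers. The phenyl group on the ring nitrogen also stays the same throughout, and a read-out at one concentration leaves open whether potency differs among compounds that read alike here.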